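From 2-methylphenyl to 2-ethylphenyl: a small expected step

A few compounds are considered here, and "the series" means these few. Any claim that something is new, unique, unknown or untested is made for them only; others in the source may bear on it.

Measured so far:
compound 1 `O=C(NCCCCl)Nc1cccc(S(=O)(=O)Oc2ccc(O)cc2)c1` gives 51000 nM in a functional assay on MCF7 cells (Homo sapiens) for cytotoxicity, read by sulforhodamine B assay, with a stated time of 48 h; a higher number here means a weaker inhibitor, a lower number a stronger inhibitor
compound 2 `Cc1ccccc1NS(=O)(=O)c1cccc(NC(=O)NCCCCl)c1` gives 52000 nM in this assay

Within the data shown here, compound 2 sits alongside compound 1 in this assay; the only measured step, a 1.0-fold higher number from compound 1 to compound 2 (0.01 log units; within the scatter), lies within the scatter, so the two cannot be told apart. Compound 3 `CCc1ccccc1NS(=O)(=O)c1cccc(NC(=O)NCCCCl)c1` differs from compound 2 by methyl in place of hydrogen on a saturated chain carbon bound to an aromatic carbon. Among the measured compounds shown here, no measured step touches this part of the molecule: the step of a 1.0-fold higher number from compound 1 to compound 2 (0.01 log units; within the scatter) exchanged the group on the sulfonyl sulfur and left the number unchanged, which shows only that a change on that end of the shared core was tolerated without effect. With nothing pointing in either direction, the estimated step of a 1.0-fold lower number from compound 2 to compound 3 (0.02 log units; within the scatter) is expected to stay within the scatter. Compound 3 is therefore expected to give about 50000 nM in this assay, with a range from 20000 nM to 125000 nM.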

Compound 3, half-maximal inhibitory concentration: 43000 nM
Estimate against measurement, compound 3: 1.2-fold (0.07 log units) above; the measured number falls inside the stated range.
By their numbers in this assay, from the lowest: compounds 3, 1 and 2 (each within the scatter of the next).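

Going from 2-methylphenyl to 2-ethylphenyl in this assay gives a 1.2-fold lower number from compound 2 to compound 3 (0.08 log units; within the scatter) and so no gain or loss can be read from it. The earlier step changed only the group on the sulfonyl sulfur, whereas this one shows that a methyl in place of hydrogen on a saturated chain carbon bound to an aromatic carbon is also tolerated, at least for this single small addition. Nothing available here bears on why the number holds steady.

The compounds shown leave open whether a longer chain such as propyl or butyl at this place would still leave the number where it is. They also leave open whether a group of another kind, such as an amine or a carboxylic acid, would produce a step beyond the scatter.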